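Swapping Fluoro for Trifluoromethyl on a Second Core

The compounds below may be only part of what the source reports. "The series", "measured", "known", "first", "only" and "open" are said of these compounds alone.

The study compares four compounds of the same broad family, measured for cytotoxicity toward human blood-derived cells. Compound 1 has the structure `Nc1ccc2oc(-c3ccc(F)cc3)cc(=O)c2c1`, and compound 2, `Nc1ccc2oc(-c3ccc(C(F)(F)F)cc3)cc(=O)c2c1`, differs from it only by trifluoromethyl in place of fluoro on an aromatic carbon. Among the compounds with values here, in an ADME assay on THP-1 cells (Homo sapiens) for cytotoxicity, read by flow cytometry and propidium iodide staining, with a stated time of 72 h (on this read-out higher numbers stand for weaker inhibition and lower numbers for stronger inhibition), compound 1 gives 10000 nM, while compound 2 gives 1900 nM, so the step of a 5.3-fold lower number from compound 1 to compound 2 (0.72 log units; beyond the scatter) is the one observation of this change so far.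

Compound 3, `CC(=O)Nc1ccc2oc(-c3cccc(F)c3)c(O)c(=O)c2c1`, carries a different core; the difference between the two cores is not broken down here. In this assay compound 3 gives 36000 nM, the highest number of the three measured compounds, with compound 1 nearest and compound 2 furthest from it.

Compound 4, `CC(=O)Nc1ccc2oc(-c3cccc(C(F)(F)F)c3)c(O)c(=O)c2c1`, has not yet been measured. It differs from compound 3 by trifluoromethyl in place of fluoro on an aromatic carbon. Within the data shown here, this is the same kind of change as the one from compound 1 to compound 2, but the place is not identical: in compound 2 the entering group sits para to a large group, in compound 4 it sits meta to a large group. Because the earlier step was a 5.3-fold lower number from compound 1 to compound 2 (0.72 log units; beyond the scatter), a lower number is expected for compound 4 too, though on a different core and place the size is uncertain. The step expected here is a 3.6-fold lower number from compound 3 to compound 4 (0.56 log units; beyond the scatter). In this assay compound 4 is therefore estimated to give 10000 nM, with a likely range from 3000 nM to 30000 nM.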

Compound 4, half-maximal inhibitory concentration: 1000 nM
Beside the measured number, compound 4's estimate is 10-fold (1.00 log units) above it; the measured number lies below the stated range.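

In this assay, trifluoromethyl in place of fluoro lowers the number again, with a 36-fold lower number from compound 3 to compound 4 (1.56 log units; beyond the scatter), so on both cores shown the change moves the number in the same direction. The size of the step does not carry over, and the two steps differ by more than the usual scatter of such measurements: the same change on two cores in this assay, a 5.3-fold lower number (0.72 log units; beyond the scatter) from compound 1 to compound 2 and a 36-fold lower number (1.56 log units; beyond the scatter) from compound 3 to compound 4, 6.8-fold (0.84 log units) apart, beyond the scatter of two such steps

This does not show why the size differs, or how large the step would be on a further core, since the two pairs differ both in their core and in where the group sits on the ring, and two pairs cannot separate those two differences.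

The compounds shown leave open whether the larger step belongs to the core of compound 3 or to the place of the group, meta to a large group, a question that the same swap at the matching place on the other core could settle. They also leave open whether the lower number is particular to trifluoromethyl or would also appear with a different group in that place, such as a chlorine atom, a methyl group or a carboxylic acid.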